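The source may hold more compounds than are shown below. What is called first, only, known or untested is meant among the compounds shown, and "the series" means these compounds.

Measured compounds:
compound 1, `O=C1CCC(=O)N1Cc1cc2nccc(-c3cc(Cl)cc4c3O[C@@H](c3ocnc3CN3CCC3)C4)c2s1`, gives "not determined" (no result reported) in an ADME assay on the whole organism (Rattus norvegicus, strain Sprague-Dawley) for pharmacokinetics, at a dose of 0.5 mg/kg by the intravenous route; a lower number here means slower removal, a higher number faster removal of the compound.
compound 2, `Cc1cc(Cl)cc(-c2ccnc3cc(CN4C(=O)C5CC5C4=O)sc23)c1O[C@@H]1CCNC[C@@H]1C`, gives "not determined" (no result reported) in this assay.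
compound 3, `Cc1cc(Cl)cc(-c2ccnc3cc(CN4C(=O)C5C(C4=O)C5(C)C)sc23)c1O[C@@H]1CCNC[C@@H]1C`, gives 1.83 mL/min/kg in this assay.

Compound 1 therefore stands nowhere on the numbers: no clearance value was reported for it, and compound 2 likewise carries no number, so compound 3 supplies the only figure in this assay. Compound 4, `Cn1nc2c(c1[C@H]1Cc3cc(Cl)cc(-c4ccnc5cc(CN6C(=O)CCC6=O)sc45)c3O1)CNCC2`, is the unmeasured compound. It differs from compound 1 at a single place, on a saturated ring carbon of a five-membered non-aromatic ring with 1 oxygen, part of a fused or bridged system of two rings, next to the ring oxygen: a group of 10 heavy atoms (7 carbon, 3 nitrogen; one five-membered aromatic ring with 2 hetero atoms, one six-membered non-aromatic ring with 1 hetero atom) in place of a group of 10 heavy atoms (7 carbon, 2 nitrogen, 1 oxygen; one four-membered non-aromatic ring with 1 hetero atom, one five-membered aromatic ring with 2 hetero atoms), on a saturated ring carbon. Compound 1 has no number in this assay. Among the compounds with values here, no step from compound 1 to compound 4 can be stated, and nothing among the measured compounds tells how large the change should be or in which direction. Within the data shown here, the only reference is compound 3, whose value of 1.83 mL/min/kg sits low. Compound 4 is expected, with wide uncertainty, to show a clearance near 3 mL/min/kg, within a range of 1 mL/min/kg to 10 mL/min/kg.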

Compound 4, clearance: 78.3 mL/min/kg
Compound 4: the middle estimate sits 26-fold (1.42 log units) below what was measured, outside the stated range (above it).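

Within the data shown here, compound 4 gives 78.3 mL/min/kg in this assay, but compound 1 has no single number there, so no step from compound 1 to compound 4 can be read. The compounds shown leave open how replacing the 4-((azetidin-1-yl)methyl)-1,3-oxazol-5-yl group changes clearance. No evidence on hand bears on this result.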